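A few compounds are considered here, and "the series" means these few. Any claim that something is new, unique, unknown or untested is made for them only; others in the source may bear on it.

Measured in an ADME assay on Huh-5-2 cells (Homo sapiens) for cytotoxicity, read by WST assay, with a stated time of 3 days; on this read-out lower numbers stand for higher toxicity in this test and higher numbers for lower toxicity in this test:
Compound 1, `O=c1c(O)c(-c2ccccc2)oc2cc(OCc3ccccc3Br)cc(O)c12`, gives > 100000 nM, which is a limit of the assay.
Compound 2, `O=c1c(O)c(-c2ccccc2)oc2cc(OCc3ccccc3[N+](=O)[O-])cc(O)c12`, gives 32000 nM.
Compound 3, `O=c1c(O)c(-c2ccccc2)oc2cc(OCc3ccc(Cl)cc3)cc(O)c12`, gives > 100000 nM, which is a limit of the assay.

Compound 3 thus stands at the limit of > 100000 nM in this assay, at which 2 of the 3 values shown sit, and only a limit is known for it. Compound 4, `O=c1c(O)c(-c2ccccc2)oc2cc(OCc3ccc([N+](=O)[O-])cc3)cc(O)c12`, differs from compound 3 by nitro in place of chloro on an aromatic carbon. Going by the values given here, two measured steps bear on this change. The step of an at least 3.1-fold lower number from compound 1 to compound 2 (0.49 log units; beyond the scatter) shows that a nitro group entering in place of a halogen brought a lower number, though there the halogen was bromo. The step of an at least 3.1-fold higher number from compound 2 to compound 3 (0.49 log units; beyond the scatter) runs the other way, but it changes the position of the group as well as its identity, so it reads less directly. On this basis a modest drop in this assay is expected from compound 3 to compound 4, namely an at least 2.0-fold lower number from compound 3 to compound 4 (0.30 log units; that floor lies within the scatter), with the caveat that compound 3 itself is only a limit. Compound 4 is therefore estimated at 50000 nM, within a range from 15000 nM to 150000 nM.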

Compound 4, half-maximal cytotoxic concentration: 93000 nM
The estimate for compound 4 lay 1.9-fold (0.27 log units) below the measured number; the measured number falls inside the stated range.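

The nitro group alone does not carry the lower number seen for compound 2: in this assay, moving it to give the 4-nitrophenyl group produces a 2.9-fold higher number from compound 2 to compound 4 (0.46 log units; beyond the scatter). Against the halogen compounds, the change reads only as floors within the scatter, an at least 1.0-fold lower number from compound 3 to compound 4 (0.03 log units; that floor lies within the scatter) and an at least 1.0-fold lower number from compound 1 to compound 4 (0.03 log units; that floor lies within the scatter), so no drop from chloro to nitro at this position is established. Both floors rest on limits of the assay: the limit of > 100000 nM in this assay, at which 2 of the 4 values shown sit.

The compounds shown leave open how far the true numbers of compound 1 and compound 3 lie beyond that limit, and so how large the change to compound 4 really is. They also leave open whether an amine or a carboxylic acid in place of chloro on this aromatic carbon would give a number as high as that of compound 4.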